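A Second Nitrile on the Aryl Ring of Compound 1

A few compounds are considered here, and "the series" means these few. Any claim that something is new, unique, unknown or untested is made for them only; others in the source may bear on it.

Compound 1 `Cc1ccc2ccc(-c3cccc(C#N)c3)cc2n1`: 7.7 nM
Compound 2 `Cc1ccc2ccc(-c3cccc(OC(F)(F)F)c3)cc2n1`: a limit only, > 10000 nM

Compound 1 stands on the only number shown. In a functional assay on CHO cells for inhibition of metabotropic glutamate receptor 5 (Rattus norvegicus), read by FLIPR and calcium flux (on this read-out higher numbers stand for weaker inhibition and lower numbers for stronger inhibition), compound 1 gives 7.7 nM. Compound 2 returns no number in this assay, only the limit > 10000 nM. The step of an at least 1200-fold higher number from compound 1 to compound 2 (3.11 log units; beyond the scatter), trifluoromethoxy in place of cyano on an aromatic carbon, therefore rests on the limit of > 10000 nM in this assay, at which 1 of the 2 values shown sits, and sets only a floor on the loss.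

Compound 3 `Cc1ccc2ccc(-c3cc(C#N)cc(C#N)c3)cc2n1` differs from compound 1 by cyano in place of hydrogen on an aromatic carbon. Going by the values given here, the one measured step bears on it only loosely: it removes the cyano, while compound 3 keeps it and adds a second. That step shows the cyano supports inhibition; it does not show what a second cyano does. No step beyond the scatter is therefore expected in this assay, and compound 3 is estimated at 10 nM, within 3 nM to 40 nM, a step of a 1.3-fold higher number from compound 1 to compound 3 (0.11 log units; within the scatter).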

Compound 3, half-maximal inhibitory concentration: 2 nM
For compound 3 the middle estimate is 5.0-fold (0.70 log units) above the measured one, and the stated range ends above it.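

In this assay a second cyano on the aromatic carbon meta to a cyano group gives a 3.9-fold lower number from compound 1 to compound 3 (0.59 log units; beyond the scatter) and so the hydrogen of compound 1 at this position can be replaced with a gain in inhibition. Compound 2 had spoken only to replacing the first nitrile, and its read-out is a limit: the limit of > 10000 nM in this assay, at which 1 of the 3 values shown sits. Nothing measured here gives a reason for the gain.

As far as these compounds go, whether the gain belongs to the nitrile itself, or would also follow from an amine, a carboxylic acid or a methyl group on the same carbon, remains open. Also open, from the compounds shown here alone, is whether a second cyano would give any gain without the first one in place, or on another carbon of the same ring.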